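Same Methyl Removed Twice, All Values at the Assay Limit

The source may hold more compounds than are shown below. What is called first, only, known or untested is meant among the compounds shown, and "the series" means these compounds.

Of the compounds shown here, three have been tested in a functional assay on HepG2 cells (Homo sapiens) for cytotoxicity, read by MTT assay, with a stated time of 48 h; a higher number here means a weaker inhibitor, a lower number a stronger inhibitor. Compound 1 `Cc1ccc2[nH]c(=O)c(-c3nc4cc([N+](=O)[O-])ccc4[nH]3)cc2c1` sits at a limit of the assay, giving > 100000 nM. Compound 2 `O=c1[nH]c2ccccc2cc1-c1nc2cc([N+](=O)[O-])ccc2[nH]1` likewise sits at a limit, giving > 100000 nM. Compound 3 `Cc1ccc2[nH]c(=O)c(-c3nc4cc(C)c(C)cc4[nH]3)cc2c1` also sits at a limit, giving > 100000 nM. Compound 2 arises from compound 1 through a single change, (hydrogen in place of methyl on an aromatic carbon), and the resulting step, a step that the two limits leave unreadable from compound 1 to compound 2, cannot be sized because of the limit of > 100000 nM in this assay, at which 3 of the 3 values shown sit. How the core of compound 3 differs from the core of compound 1 is not broken down here.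

Compound 4 `Cc1cc2nc(-c3cc4ccccc4[nH]c3=O)[nH]c2cc1C` has not yet been measured. It arises from compound 3 through the same change, (hydrogen in place of methyl on an aromatic carbon), at the same kind of position on the shared core. For the measured compounds named here, the earlier step from compound 1 to compound 2 showed nothing that could be read, and every value so far rests at the same limit. Compound 4 is therefore expected to follow suit, with an estimated step that the limit leaves unreadable from compound 3 to compound 4 that leaves it at the limit. The estimate for compound 4 is 150000 nM, between 60000 nM and 500000 nM.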

Compound 4, half-maximal inhibitory concentration: > 100000 nM
Compound 4 gave a limit, no number (the forecaster's own chance of this, stated with the estimate: 85%); the middle value lies beyond the limit too.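

In this assay no size can be read for the change of methyl to hydrogen between compound 3 and compound 4, because both give a limit and not a number: (the limit of > 100000 nM in this assay, at which 4 of the 4 values shown sit). Compounds 1 to 4 leave open how strong any of them really is, and whether this change alters that strength at all.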